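A few compounds are considered here, and "the series" means these few. Any claim that something is new, unique, unknown or untested is made for them only; others in the source may bear on it.

Of the compounds shown here, three have been tested in a functional assay, tested at 100 ug/mL; on this read-out lower numbers stand for a weaker effect and higher numbers for a stronger effect at the one concentration tested. Compound 1 `O=S(=O)(CC1=NCCS1)c1n[nH]cc1-c1ccccc1` is recorded as "not active" (no number reported) in this assay. Compound 2 `O=S(=O)(CC1=NCCS1)c1c(-c2ccc(Cl)cc2)noc1-c1ccc(Cl)cc1` is likewise recorded as "not active" (no number reported) in this assay, with no number attached, so compound 2 stands among the two entries for which no figure exists, while compound 3 `COc1ccc(C2=NOC(c3ccc(C)cc3)C2S(=O)(=O)CC2=NCCS2)cc1` is the only one with a measured figure, giving 52.6% in this assay. Within the data shown here, no two measured compounds differ in just one place, so no measured step is available to lean on.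

Compound 4 `O=S(=O)(CC1=NCCO1)c1c(-c2ccc(Cl)cc2)noc1-c1ccc(Cl)cc1` has not yet been tested. It is derived from compound 2 by one exchange: a group of 5 heavy atoms (3 carbon, 1 nitrogen, 1 oxygen; one five-membered non-aromatic ring with 2 hetero atoms) in place of a group of 5 heavy atoms (3 carbon, 1 nitrogen, 1 sulfur; one five-membered non-aromatic ring with 2 hetero atoms), on a saturated chain carbon bound to a sulfonyl sulfur. With compound 2 reported without any number, the most that can be said is that a change of this kind, swapping one hetero atom inside a small non-aromatic ring, gives no reason in the data shown to expect a jump beyond the usual scatter of this assay. Compound 4 is therefore estimated at 10% in this assay, within a range from 0% to 30%.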

Compound 4, a percentage reported as activity, at one concentration (the size of the read-out at that concentration, not a potency): "not active" (no number reported)
Nothing numeric was reported for compound 4; no gap can be computed for the estimate.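

In this assay compound 2 and compound 4 both carry no number, so no step can be read between them. Nothing shown bears on why this is so. The compounds shown leave open whether exchanging the ring sulfur for oxygen changes the read-out where the core gives a measurable effect.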